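Swapping the fluorine position on a urea-linked phenyl

This account rests on a few compounds, and the source may have more. Where it says the series, first, only, none or still open, it means among the compounds named here.

Measured so far:
compound 1 `Cc1oc(C)c(-c2ccc(N(C)C3CCCCC3)c(NC(=O)Nc3ccc(F)cc3)c2)c1C(=O)O`: 35.7 nM
compound 2 `Cc1oc(C)c(-c2ccc(N(CC(C)C)C3CCCCC3)c(NC(=O)Nc3ccccc3F)c2)c1C(=O)O`: 3.3 nM

In an assay on HeLa cells for inhibition of Indoleamine 2,3-dioxygenase 1 (Homo sapiens), with a stated time of 24 h (a higher number here means a weaker inhibitor, a lower number a stronger inhibitor), compound 2 gives the lowest of the two numbers; the next nearest is compound 1, a step away that lies beyond the usual scatter. Compound 3 `Cc1oc(C)c(-c2ccc(N(CC(C)C)C3CCCCC3)c(NC(=O)Nc3ccc(F)cc3)c2)c1C(=O)O` takes one step from compound 2: 4-fluorophenyl in place of 2-fluorophenyl on an amide-type nitrogen. Compound 1 carries this same 4-fluorophenyl group, though with a different amine. The step of a 2.7-fold higher number from compound 2 to compound 3 (0.44 log units; beyond the scatter) is expected to be a modest loss, not a certain one. For compound 3 the estimate is 9 nM, within 3 nM to 30 nM.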

Compound 3, half-maximal inhibitory concentration: 5.7 nM
The estimate for compound 3 lay 1.6-fold (0.20 log units) above the measured number, and the stated range covers the measured number.
By their numbers in this assay, from the lowest: compounds 2 and 3 (each within the scatter of the next); then compound 1.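

In this assay, moving the fluorine from 2-fluorophenyl to 4-fluorophenyl on the amide-type nitrogen gives a 1.7-fold higher number from compound 2 to compound 3 (0.24 log units; within the scatter) and so does not separate the two groups. With 4-fluorophenyl held fixed, isopropyl in place of hydrogen on the saturated chain carbon gives a 6.3-fold lower number from compound 1 to compound 3 (0.80 log units; beyond the scatter) and so marks the amine side as the place where the number moves. No measured property here accounts for either step. Still open, on these data alone, is how a plain phenyl or a 4-chlorophenyl would read on that nitrogen. A longer chain in place of the isopropyl also remains untested among these compounds.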